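Swapping methylsulfanyl for methoxy in compound 3

The compounds below may be only part of what the source reports. "The series", "measured", "known", "first", "only" and "open" are said of these compounds alone.

compound 1 `COc1cc(-c2ocnc2-c2cc(Br)c(OC)c(OC)c2)ccc1SC` – 260 nM
compound 2 `COc1cc(-c2ocnc2-c2cc(OC)c(OC)c(OC)c2)ccc1SC` – 430 nM
compound 3 `COc1ccc(-c2ocnc2-c2cc(Br)c(OC)c(OC)c2)cc1SC` – 520 nM

All three values come from an ADME assay on HaCaT cells (Homo sapiens) for cytotoxicity, read by MTT assay, with a stated time of 48 h (on this read-out higher numbers stand for weaker inhibition and lower numbers for stronger inhibition), and compound 3 stands within the scatter of both compound 1 and compound 2. Compound 4 `COc1ccc(-c2ocnc2-c2cc(Br)c(OC)c(OC)c2)cc1OC` is compound 3 with one change, methoxy in place of methylsulfanyl on an aromatic carbon. Within the data shown here, no measured pair shows this exact swap. The closest guide is a different swap, methoxy in place of bromo on an aromatic carbon, which gave a 1.7-fold higher number from compound 1 to compound 2 (0.22 log units; within the scatter). So no step beyond the scatter is expected in this assay. The expected step is a 1.3-fold lower number from compound 3 to compound 4 (0.11 log units; within the scatter). For compound 4 the estimated value is 400 nM, with an expected range from 170 nM to 1000 nM.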

Compound 4, half-maximal inhibitory concentration: 10100 nM
Compound 4: the middle estimate sits 25-fold (1.40 log units) below what was measured, outside the stated range (above it).
By their numbers in this assay, from the lowest: compounds 1, 2 and 3 (each within the scatter of the next); then compound 4.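

In this assay, among these compounds, the sulfur atom turns out to matter far more than the earlier compounds could show: replacing methylsulfanyl with methoxy, which has the same heavy-atom count, gives a 19-fold higher number from compound 3 to compound 4 (1.29 log units; beyond the scatter) and so much weaker inhibition. The same swap gives a 39-fold higher number from compound 1 to compound 4 (1.59 log units; beyond the scatter) even though compound 1 carries its methylsulfanyl at a different place on that ring, so both placements lose strength once the sulfur group is gone. No measurement at hand explains this jump. From the compounds shown here alone, whether a longer sulfur chain such as ethylsulfanyl, or an amine, would keep the lower numbers remains open.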